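Chloro for cyano on the piperazine aryl of compound 1

The compounds below may be only part of what the source reports. "The series", "measured", "known", "first", "only" and "open" are said of these compounds alone.

Compound 1 `Cc1nc(-c2ccccc2)c(C(=O)N2CCN(c3cccc(C#N)c3)CC2)o1` is the weakest performer of the three measured compounds in an ADME assay on microsomes from liver (Mus musculus) for metabolic stability, read by LC-MS, with a stated time of 1 h, tested at 5 uM (a higher number here means that more of the compound is left, a lower number that less of the compound is left), where compound 1 gives 1.6%. Compound 2 `Cc1nc(-c2ccccc2)c(C(=O)N2CCN(c3cccc(C)c3C)CC2)o1` shares the core of compound 1, and compound 2 gives 83.6%; compound 3 `CCC[C@H](Nc1nc(-c2ccc(NC(=O)NCC)c(OC)c2)ncc1C)c1cccnc1`, built on a different scaffold, gives 87.5%. Among the measured compounds shown here, the nearest neighbour of compound 1 is compound 2, and the one step measured, a number 82 percentage points higher from compound 1 to compound 2 (beyond the scatter), comes from 2,3-dimethylphenyl in place of 3-cyanophenyl on an amine nitrogen in a ring.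

Compound 4 `Cc1nc(-c2ccccc2)c(C(=O)N2CCN(c3cccc(Cl)c3)CC2)o1` differs from compound 1 by chloro in place of cyano on an aromatic carbon, that is, 3-cyanophenyl to 3-chlorophenyl. For the measured compounds named here, only the step from compound 1 to compound 2 bears on this change, and it touches the same ring but replaces the whole aryl rather than one substituent; no measured pair isolates chloro for cyano. That one step was large and points towards more compound remaining, so a rise in this assay is expected for compound 4, though smaller and far less certain than the change to compound 2. Compound 4 is therefore estimated at 35%, with a range from 5% to 80%, meaning an expected step of a number 33.4 percentage points higher from compound 1 to compound 4 (beyond the scatter).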

Compound 4, percent of the compound remaining: 2%
Compound 4: the middle estimate sits 33 percentage points above what was measured; the measured number lies below the stated range.
By their numbers in this assay, from the lowest: compounds 1 and 4 (each within the scatter of the next); then compounds 2 and 3 (each within the scatter of the next).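

Chloro in place of cyano on the aromatic carbon, meta to a large group, gives a number 0.4 percentage points higher from compound 1 to compound 4 (within the scatter) in this assay, so at this position the two substituents cannot be told apart in this read-out. The high number of compound 2 therefore does not follow from replacing cyano with just any other single substituent at this position, and 3-chlorophenyl in place of 2,3-dimethylphenyl gives a number 81.6 percentage points lower from compound 2 to compound 4 (beyond the scatter). Nothing available on these compounds explains the gap between these aryl groups.

From the compounds shown here alone, the step between 2,3-dimethylphenyl and 3-chlorophenyl changes more than one substituent, so it remains open whether the difference lies with the methyl on the carbon that carries chloro in compound 4, with the second methyl, or with the two together. A 3-methylphenyl or a 2-methylphenyl on the same piperazine nitrogen, with the core of compound 1 unchanged, would separate these readings, and a 3-methoxyphenyl would show whether another group on this carbon behaves like methyl or like chloro and cyano.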